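Esterifying a hydroxyl: from compound 2 to a tosylate

A few compounds are considered here, and "the series" means these few. Any claim that something is new, unique, unknown or untested is made for them only; others in the source may bear on it.

Two compounds from this series share a sugar-like core and a five-membered heteroaromatic ring and have been tested in a functional assay on A549 cells (Homo sapiens) for antiproliferative activity, read by sulforhodamine B assay, with a stated time of 48 h; on this read-out lower numbers stand for stronger inhibition of growth and higher numbers for weaker inhibition of growth. Compound 1 `COc1cc(-c2nc(CO[C@@H]3O[C@H](CSc4ncn[nH]4)[C@H]4OC5(CCCC5)O[C@@H]34)no2)cc(OC)c1OC` gives 28000 nM. Compound 2 `O=[N+]([O-])c1ccc(-c2nc(CO[C@@H]3O[C@H](CO)[C@H]4OC5(CCCC5)O[C@@H]34)no2)cc1` gives 32000 nM. Compound 2 nominally carries the larger of the two numbers, but its gap to compound 1 is within the scatter, so the two cannot be told apart on this read-out.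

Compound 3 `Cc1ccc(S(=O)(=O)OC[C@H]2O[C@@H](OCc3noc(-c4ccc([N+](=O)[O-])cc4)n3)[C@@H]3OC4(CCCC4)O[C@@H]32)cc1` is compound 2 with one change: (4-methylphenyl)sulfonyl in place of hydrogen on an oxygen on a saturated carbon. Going by the values given here, no pair of measured compounds shows a step of this kind, so there is no direct guide to its effect. Given that, the step from compound 2 to compound 3 is expected to be small, as a 1.5-fold lower number from compound 2 to compound 3 (0.16 log units; within the scatter), with no clear direction beyond the scatter. Compound 3 is therefore estimated at 22000 nM in this assay, within a range of 6000 nM to 70000 nM.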

Compound 3, concentration for 50% growth inhibition: > 100000 nM
Compound 3: only a limit was reported; the forecaster's own chance of this, stated with the estimate: 15%; middle value at least 4.5-fold (0.65 log units) away from the limit.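

Going by these compounds alone, until now no step at this position could be read. This oxygen on a saturated carbon now proves sensitive, since (4-methylphenyl)sulfonyl in place of hydrogen gives an at least 3.1-fold higher number from compound 2 to compound 3 (0.49 log units; beyond the scatter) in this assay. For compound 3, the reported > 100000 nM is a limit of the assay and not a number. The step therefore sets only a minimum for the weakening of growth inhibition, and the true size stays unknown: the limit of > 100000 nM in this assay, at which 1 of the 3 values shown sits.

The compounds shown cannot separate the effect of removing the hydroxyl hydrogen from the effect of adding the aromatic ring and sulfonyl group. A methyl ether or an acetate ester on the same oxygen would test the first without the second, and an amine in place of the hydroxy group would show whether this position tolerates any other group.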